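A few compounds are considered here, and "the series" means these few. Any claim that something is new, unique, unknown or untested is made for them only; others in the source may bear on it.

Measured compounds:
- compound 1 `O=C(NO)c1cccc(C(=O)NCc2ccccc2)c1`, 34 nM
- compound 2 `CNC(=O)c1cccc(C(=O)NO)c1`, 2500 nM

Both were tested in an assay on isolated protein for inhibition of protein deacetylase HDAC6 (Homo sapiens), read by fluorescence, with a stated time of 60 min; on this read-out lower numbers stand for stronger inhibition and higher numbers for weaker inhibition. Among the compounds with values here, compound 2 gives the highest of the two numbers, the one from compound 1 lying far below it, as the step of a 74-fold higher number from compound 1 to compound 2 (1.87 log units; beyond the scatter) shows. Compound 3 `Cc1cccc(C(=O)NO)c1` differs from compound 2 by methyl in place of methylcarbamoyl on an aromatic carbon. Within the data shown here, only that one step bears on the change, and it was large; the remaining methylcarbamoyl is now removed entirely, so a further weakening is expected, smaller in size. The expected step is a 2.4-fold higher number from compound 2 to compound 3 (0.38 log units; beyond the scatter). Compound 3 is therefore estimated at 6000 nM, within a range from 2000 nM to 20000 nM.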

Compound 3, half-maximal inhibitory concentration: 650 nM
Compound 3: the middle estimate sits 9.2-fold (0.97 log units) above what was measured; measured number outside the range, below it.
By their numbers in this assay, from the lowest: compound 1; then compound 3; then compound 2.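

Swapping methylcarbamoyl for methyl on this aromatic carbon gives a 3.8-fold lower number from compound 2 to compound 3 (0.59 log units; beyond the scatter), so the smaller group does better here. The earlier step showed only that losing the phenyl weakens inhibition; this one shows that the amide left behind in compound 2 brings no gain at this place. No measurement on hand explains why the methyl compound gives the lower number.

Going by these compounds, whether an amine, a carboxylic acid or a longer alkyl chain at this position would give a lower or a higher number than methyl stays open. So does what plain hydrogen would give there.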